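Trifluoromethoxy for methoxy on the pendant aryl group

The source may report more compounds than this note shows. Statements on the series, on what has been measured and on what is new or still open speak of the compounds shown alone.

Measured so far in an assay on HEK293 cells for displacement of a labelled ligand from 5-hydroxytryptamine receptor 7 (Rattus norvegicus), read by radioligand binding; on this read-out lower numbers stand for stronger inhibition and higher numbers for weaker inhibition:
compound 1, `CCn1nc2c(c1-c1ccccc1)CCNCC2`: 140 nM
compound 2, `c1ccc(-c2c3c(nn2C2CCC2)CCNCC3)cc1`: 90 nM
compound 3, `COc1ccc(-c2c3c(nn2C(C)C)CCNCC3)cc1`: 18 nM

Compound 3 gives the lowest number of the three in this assay; both compound 2 and compound 1 lie above it by more than the scatter, so compound 3 is the most potent of the measured set.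

Compound 4, `CC(C)n1nc2c(c1-c1ccc(OC(F)(F)F)cc1)CCNCC2`, differs from compound 3 only in that (trifluoromethyl in place of methyl on an oxygen on an aromatic ring). Within the data shown here, the one measured step, a 1.6-fold lower number from compound 1 to compound 2 (0.19 log units; within the scatter), concerns the substituent on the aromatic nitrogen and says nothing about the group on the aryl ring. Among the measured compounds shown here, no measured step bears on this change, so no shift beyond the scatter is expected for compound 4. Compound 4 is estimated at 25 nM, range 8 nM to 80 nM, which means an expected step of a 1.4-fold higher number from compound 3 to compound 4 (0.14 log units; within the scatter).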

Compound 4, inhibition constant: 5000 nM
Estimate against measurement, compound 4: 200-fold (2.30 log units) below; measured number outside the range, above it.
By their numbers in this assay, from the lowest: compound 3; then compounds 2 and 1 (each within the scatter of the next); then compound 4.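

In this assay, the group on the oxygen on the aromatic ring proves decisive: trifluoromethyl in place of methyl gives a 280-fold higher number from compound 3 to compound 4 (2.44 log units; beyond the scatter) as the step. The only earlier step between compounds differing in one place, a 1.6-fold lower number from compound 1 to compound 2 (0.19 log units; within the scatter) at the aromatic nitrogen, stayed within the scatter, so this is the first change in the series shown to move the number beyond it. Nothing available here accounts for the loss.

As far as these compounds go, it remains open whether ethoxy, hydroxyl or a chlorine atom in place of methoxy would hold the number of compound 3 or lose it as trifluoromethoxy does.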